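From a phenethyl ketone to an aminopropyl analogue

This account rests on a few compounds, and the source may have more. Where it says the series, first, only, none or still open, it means among the compounds named here.

Compound 2 `O=C(CCc1ccccc1)c1ccn(-c2ccc3c(c2)B(O)OC3)c1` carries a phenethyl group on the carbonyl carbon of the shared core. In an ADME assay on L929 cells (Mus musculus) for cytotoxicity, read by resazurin assay, with a stated time of 72 h (a lower number here means a stronger inhibitor, a higher number a weaker inhibitor), compound 2 gives > 10 ug/mL, which is a limit of the assay rather than a number. Its neighbour compound 1 `COc1ccccc1C(=O)c1ccn(-c2ccc3c(c2)B(O)OC3)c1` bears a 2-methoxyphenyl group in that place. In this assay compound 1 gives > 10 ug/mL, again a limit. The step between them, a step that the two limits leave unreadable from compound 1 to compound 2, therefore cannot be read in size, and the limit of > 10 ug/mL in this assay, at which 2 of the 2 values shown sit, is all the data show. Compound 3 `NCCCC(=O)c1ccn(-c2ccc3c(c2)B(O)OC3)c1` differs from compound 2 by aminomethyl in place of phenyl on a saturated chain carbon, two bonds along the chain from a carbonyl carbon. Going by the values given here, no measured step bears on this change, so no direction can be drawn from the values in hand. Compound 3 is expected to sit at or beyond the same limit, with a step that the limit leaves unreadable from compound 2 to compound 3 that is estimated only loosely. The estimate for compound 3 is 30 ug/mL, with a range from 8 ug/mL to 100 ug/mL.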

Compound 3, half-maximal inhibitory concentration: > 10 ug/mL
Compound 3 ended at the assay's limit (the forecaster's own chance of this, stated with the estimate: 85%); the middle value is on the limit's open side.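

In this assay compound 3 gives > 10 ug/mL, which is a limit of the assay and not a number. No step among compound 1, compound 2 and compound 3 can be read in size: the limit of > 10 ug/mL in this assay, at which 3 of the 3 values shown sit.

The compounds shown leave open whether aminomethyl in place of phenyl changes the result at all.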